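The source may report more compounds than this note shows. Statements on the series, on what has been measured and on what is new or still open speak of the compounds shown alone.

Going by the values given here, in an ADME assay on a cell-free system (plasma, Mus musculus) for protein binding (on this read-out higher numbers stand for a larger free fraction and lower numbers for a smaller free fraction), compound 2 `N#Cc1ccc(OCCCN2CCC(C(O)(c3ccccn3)c3nccs3)CC2)cc1` gives 0.079, the lower of the two numbers so far, while compound 1 `NS(=O)(=O)c1ccc(OCCCN2CCC(C(O)(c3cccc(F)c3)c3nccs3)CC2)cc1` gives 0.166. Compound 3 `NS(=O)(=O)c1ccc(OCCCN2CCC(C(O)(c3ccccn3)c3nccs3)CC2)cc1` has sulfamoyl in place of cyano on an aromatic carbon of compound 2 (sulfamoyl in place of cyano on an aromatic carbon). Sulfamoyl also appears in compound 1 at 0.166, but this single example gives only loose guidance. A moderate upward move, beyond the scatter, is therefore expected, and the estimated step is a 2.3-fold higher number from compound 2 to compound 3 (0.36 log units; beyond the scatter). The unbound fraction of compound 3 is estimated at 0.18, with an expected range of 0.1 to 0.3.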

Compound 3, unbound fraction: 0.178
The estimate for compound 3 lay 1.0-fold (0.00 log units) above the measured number; measured number inside the range.
By their numbers in this assay, from the lowest: compound 2; then compounds 1 and 3 (each within the scatter of the next).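

In this assay, sulfamoyl in place of cyano, para to a large group on the six-membered aromatic ring, gives a 2.3-fold higher number from compound 2 to compound 3 (0.35 log units; beyond the scatter), so a change at this position can shift the reading. With sulfamoyl kept, pyridin-2-yl in place of 3-fluorophenyl gives a 1.1-fold higher number from compound 1 to compound 3 (0.03 log units; within the scatter), so this exchange does not separate the two compounds. No measurement shown here accounts for the sulfamoyl step. Going by these compounds, it remains open whether that step also holds with 3-fluorophenyl in the molecule, and how an amine or a carboxylic acid at the same position would read.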